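Changing the Ring on the Carbon Double-Bonded to Nitrogen

This account rests on a few compounds, and the source may have more. Where it says the series, first, only, none or still open, it means among the compounds named here.

Of the compounds shown here, three built on one shared core have been tested in an ADME assay on NIH3T3 cells (Mus musculus) for cytotoxicity, read by MTT assay, with a stated time of 24 h; on this read-out higher numbers stand for weaker inhibition and lower numbers for stronger inhibition. Compound 1 `O=C(CSc1nnc(-c2ccncc2)o1)N/N=C/c1ccccc1F` gives 142000 nM. Compound 2 `O=C(CSc1nnc(-c2ccncc2)o1)N/N=C/c1ccccc1O` gives 155000 nM. Compound 3 `O=C(CSc1nnc(-c2ccncc2)o1)N/N=C/c1cc(Br)cc(Br)c1O` gives 190000 nM. Compound 3 is not set apart from the other two: the steps to it are a 1.3-fold higher number from compound 1 to compound 3 (0.13 log units; within the scatter) and a 1.2-fold higher number from compound 2 to compound 3 (0.09 log units; within the scatter), and the remaining step is a 1.1-fold higher number from compound 1 to compound 2 (0.04 log units; within the scatter).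

Compound 4 `O=C(CSc1nnc(-c2ccncc2)o1)N/N=C/c1ccc(O)c(O)c1` has not yet been measured. It differs from compound 3 in one place: 3,4-dihydroxyphenyl in place of 3,5-dibromo-2-hydroxyphenyl on a carbon with a double bond to nitrogen. The two steps that bear on this change are those that also exchange the ring on this carbon, from compound 1 and from compound 2 to compound 3, and both stayed within the scatter. Compound 4 is therefore expected to show no step beyond the scatter, an estimated 1.1-fold lower number from compound 3 to compound 4 (0.05 log units; within the scatter). The expected value for compound 4 in this assay is 170000 nM, with a range from 85000 nM to 340000 nM.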

Compound 4, half-maximal inhibitory concentration: 154000 nM
The estimate for compound 4 lay 1.1-fold (0.04 log units) above the measured number; low and high end bracket the measured number.
By their numbers in this assay, from the lowest: compounds 1, 4, 2 and 3 (each within the scatter of the next).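

Placing 3,4-dihydroxyphenyl on the carbon with a double bond to nitrogen leaves the number in this assay within the usual scatter of each of the three earlier compounds (a 1.2-fold lower number from compound 3 to compound 4 (0.09 log units; within the scatter); a 1.0-fold lower number from compound 2 to compound 4 (0.00 log units; within the scatter); a 1.1-fold higher number from compound 1 to compound 4 (0.04 log units; within the scatter)). The earlier compounds shown here covered fluoro, hydroxy and dibromo-hydroxy rings, and this fourth ring extends that set with a second hydroxy group and no halogen, yet all four compounds remain indistinguishable on this read-out. No supporting information is available to explain why these ring changes leave the number so flat.

All four groups at this position are substituted phenyl rings, so an amine or a carboxylic acid on the ring remains an open case. Going by these compounds, replacing the ring with a longer carbon chain is equally open, and either change might or might not move the number beyond the scatter.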